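A halogen swap on a weak antiproliferative quinoline amide

The source may hold more compounds than are shown below. What is called first, only, known or untested is meant among the compounds shown, and "the series" means these compounds.

Measured so far:
Compound 1 `CCN1CCN(c2cc(C)c3cc(NC(=O)c4cccc(Cl)c4)ccc3n2)CC1` gives 17800 nM in a functional assay on SK-BR-3 cells (Homo sapiens) for antiproliferative activity, read by MTT assay, with a stated time of 72 h; a higher number here means a weaker inhibitor, a lower number a stronger inhibitor.
Compound 2 `Cc1cc(NCCN2CCCC2)nc2ccc(NC(=O)c3ccc(Cl)c(Cl)c3)cc12` gives 9530 nM in this assay.
Compound 3 `Cc1cc(NCCN2CCCCC2)nc2ccc(NC(=O)c3ccc(Cl)c(Cl)c3)cc12` gives 1800 nM in this assay.

Compound 1 has the highest of the three numbers. Its gap to compound 2 lies within the scatter, so the two cannot be told apart; only compound 3 stands clearly apart from it as the stronger inhibitor. Among the measured pairs there is one single-point step, a 5.3-fold lower number from compound 2 to compound 3 (0.72 log units; beyond the scatter), which concerns the saturated amine ring on the side chain and says nothing about the amide-bearing aromatic ring.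

Compound 4 `CCN1CCN(c2cc(C)c3cc(NC(=O)c4cccc(F)c4)ccc3n2)CC1` differs from compound 1 in one place: fluoro in place of chloro on an aromatic carbon. Going by the values given here, no measured pair shows what swapping one halogen for another at this aromatic carbon does in this assay. Among the compounds with values here, with no step to lean on, the expectation is a number close to that of compound 1, with the change a 1.2-fold higher number from compound 1 to compound 4 (0.09 log units; within the scatter) expected to stay within the scatter. Compound 4 is therefore estimated at 22000 nM, with a range from 7000 nM to 60000 nM, and it is expected to remain a weak inhibitor in this assay.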

Compound 4, half-maximal inhibitory concentration: 24900 nM
Beside the measured number, compound 4's estimate is 1.1-fold (0.05 log units) below it, within the range that was stated.
By their numbers in this assay, from the lowest: compound 3; then compounds 2, 1 and 4 (each within the scatter of the next, the first and the last beyond it).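

Going by these compounds alone, at the aromatic carbon that holds the chloro group in compound 1, the measured swap to fluoro gives a 1.4-fold higher number from compound 1 to compound 4 (0.15 log units; within the scatter) in this assay and is the first direct reading of a halogen exchange at this position. The 3-chlorophenyl and 3-fluorophenyl amides therefore cannot be told apart in this read-out, and with this core and side chain, both halogens leave the compound a weak inhibitor. No measurement shown here explains this outcome.

Going by these compounds, whether a group other than a halogen at this carbon, such as methoxy, a nitrile or an amine, would give a number clearly apart from that of compound 1 remains open. Also open is whether fluoro in place of chloro would read the same on the much stronger compound 3, since the only halogen exchange shown comes from the weak end of this small set.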